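The source may hold more compounds than are shown below. What is called first, only, known or untested is meant among the compounds shown, and "the series" means these compounds.

The compounds measured so far:
compound 1 `COc1ccccc1N1CCN(CC(=O)C(O)(c2ccccc2)C2CCC2)CC1`: in a functional assay on ileum for antagonist activity at muscarinic acetylcholine receptor M3 (Cavia porcellus) (a lower number here means a stronger inhibitor, a higher number a weaker inhibitor), compound 1 gives > 10000 nM, a limit of the assay.
compound 2 `O=C(CN1CCN(C/C=C\c2ccccc2)CC1)C(O)(c1ccccc1)C1CCC1`: in this assay compound 2 gives 9.92 nM.
compound 3 `O=C(CN1CCN(c2ccc([N+](=O)[O-])cc2)CC1)C(O)(c1ccccc1)C1CCC1`: in this assay compound 3 gives > 10000 nM, again a limit of the assay.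

Compound 3 therefore stands at the weak end of what has been seen, a position shared with compound 1, as the limit of > 10000 nM in this assay, at which 2 of the 3 values shown sit, shows. The step of an at least 1000-fold higher number from compound 2 to compound 3 (3.00 log units; beyond the scatter) was large, and the step that the two limits leave unreadable from compound 1 to compound 3 cannot be read from two limits.

Compound 4 `O=C(CN1CCN(CC(=O)C(O)(c2ccccc2)C2CCC2)CC1)N1CCCC1` differs from compound 3 in one place: ((pyrrolidin-1-yl)carbonyl)methyl in place of 4-nitrophenyl on an amine nitrogen in a ring. Among the measured compounds shown here, of the measured steps, an at least 1000-fold lower number from compound 1 to compound 2 (3.00 log units; beyond the scatter) bears on this most directly, in that it shows the only non-aryl group on the ring nitrogen giving the one strong value; an at least 1000-fold higher number from compound 2 to compound 3 (3.00 log units; beyond the scatter) shows the same contrast from the other side. Compound 4 likewise carries a non-aryl group there, though not the 3-phenylprop-2-en-1-yl of compound 2, so a step downward in this assay is expected, of the size an at least 25-fold lower number from compound 3 to compound 4 (1.39 log units; beyond the scatter), but smaller than the step to compound 2. Compound 4 is thus estimated at 400 nM, within 40 nM to 5000 nM.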

Compound 4, antagonist equilibrium constant: 210 nM
The estimate for compound 4 lay 1.9-fold (0.28 log units) above the measured number; measured number inside the range.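

Placing ((pyrrolidin-1-yl)carbonyl)methyl on the amine nitrogen in the ring gave, in this assay, an at least 47-fold lower number from compound 3 to compound 4 (1.67 log units; beyond the scatter), and the same group in place of 2-methoxyphenyl gave an at least 47-fold lower number from compound 1 to compound 4 (1.67 log units; beyond the scatter), so among these compounds a strong value no longer depends on 3-phenylprop-2-en-1-yl alone. That group does not match compound 2, however, with a 21-fold higher number from compound 2 to compound 4 (1.33 log units; beyond the scatter), which shows that the two groups carried directly through a saturated chain carbon at this nitrogen are not equal. The two compounds with an aromatic ring bound directly to this nitrogen, compound 1 and compound 3, remain at the weak end, each at a limit of the assay: the limit of > 10000 nM in this assay, at which 2 of the 4 values shown sit.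

The compounds shown leave open how a benzyl group or a plain propyl chain at this nitrogen would compare with compound 2 and compound 4. They also leave open whether a diethylamide in place of the pyrrolidine amide would keep the value of compound 4.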